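A few compounds are considered here, and "the series" means these few. Any claim that something is new, unique, unknown or untested is made for them only; others in the source may bear on it.

In an ADME assay on microsomes from liver (Homo sapiens) for metabolic stability, with a stated time of 10 min, tested at 0.5 uM (a higher number here means that more of the compound is left, a lower number that less of the compound is left), compound 3 `Cc1noc(-c2ccccc2)c1[C@@H]1C[C@@](C)(c2ccc(F)cc2F)N=C(N)S1` gives 39% as the middle of three values, with compound 1 `Cc1noc(C)c1[C@@H]1C[C@@](C)(c2ccc(F)cc2F)N=C(N)S1` at 24% and compound 2 `Cc1noc(C)c1[C@@H]1C[C@@](C)(c2ccc(F)cc2)N=C(N)S1` at 73% on either side. Compound 4 `Cc1noc(-c2ccc(F)cc2)c1[C@@H]1C[C@@](C)(c2ccc(F)cc2F)N=C(N)S1` differs from compound 3 by one change, fluoro in place of hydrogen on an aromatic carbon. Within the data shown here, two measured steps bear on it. Among the measured compounds shown here, the one exchange of fluoro and hydrogen, made on the other aromatic ring, is the large step of a number 49 percentage points higher from compound 1 to compound 2 (beyond the scatter) with hydrogen entering, so fluoro entering here points weakly downward. The phenyl itself came with the modest step of a number 15 percentage points higher from compound 1 to compound 3 (beyond the scatter) and says nothing about its substitution. Only a small fall is expected (a number 4 percentage points lower from compound 3 to compound 4 (within the scatter)) and it would lie within the scatter. Compound 4 is estimated at 35% (range 18% to 55%).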

Compound 4, percent of the compound remaining: 45%
For compound 4 the middle estimate is 10 percentage points below the measured one, and the stated range covers the measured number.
By their numbers in this assay, from the lowest: compound 1; then compounds 3 and 4 (each within the scatter of the next); then compound 2.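

In this assay, the exchange of phenyl to 4-fluorophenyl gives only a number 6 percentage points higher from compound 3 to compound 4 (within the scatter), so fluoro at this place, para to a large group, shows no effect that stands clear of the scatter. The 4-fluorophenyl group still compares with methyl as a number 21 percentage points higher from compound 1 to compound 4 (beyond the scatter). The exchange of hydrogen and fluoro does not read alike across the two places tested: the same change on two cores in this assay, a number 49 percentage points higher (beyond the scatter) from compound 1 to compound 2 and a number 6 percentage points lower (within the scatter) from compound 4 to compound 3, 55 percentage points apart, beyond the scatter of two such steps

Open, from the compounds shown here alone, is how an amine, a carboxylic acid or a methoxy group would read at this place. Also open, going by these compounds, is how phenyl or 4-fluorophenyl would read on the core of compound 2.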